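The compounds below may be only part of what the source reports. "The series", "measured", "known", "first", "only" and "open" are said of these compounds alone.

Working notes on the series.

The shared core is a dipeptide-like chain with a naphthyloxyacetyl cap and a free carboxylic acid, varied only at the group on the oxygen or sulfur on the saturated carbon next to the ketone. Compound 1 `CC(C)[C@H](NC(=O)COc1cccc2ccccc12)C(=O)N[C@@H](CC(=O)O)C(=O)CSc1nnnn1C` carries (1-methyl-1H-tetrazol-5-yl)sulfanyl there. In a functional assay on Jurkat cells (Homo sapiens) for inhibition (a lower number here means a stronger inhibitor, a higher number a weaker inhibitor), compound 1 gives only a limit, > 200000 nM. Compound 2 `CC(C)[C@H](NC(=O)COc1cccc2ccccc12)C(=O)N[C@@H](CC(=O)O)C(=O)COc1ccncn1` carries (pyrimidin-4-yl)oxy. In this assay compound 2 also gives only a limit, > 200000 nM. Compound 3 `Cc1cc(OCC(=O)[C@H](CC(=O)O)NC(=O)[C@@H](NC(=O)COc2cccc3ccccc23)C(C)C)nc(C)n1` carries (2,6-dimethylpyrimidin-4-yl)oxy. In this assay compound 3 again reaches only a limit, > 200000 nM.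

Where compound 3 stands therefore cannot be placed against its neighbours: the steps a step that the two limits leave unreadable from compound 1 to compound 2, a step that the two limits leave unreadable from compound 1 to compound 3 and a step that the two limits leave unreadable from compound 2 to compound 3 are all unreadable, since every value sits at the limit of > 200000 nM in this assay, at which 3 of the 3 values shown sit.

Compound 4 `CC(C)[C@H](NC(=O)COc1cccc2ccccc12)C(=O)N[C@@H](CC(=O)O)C(=O)COc1cncc2ccccc12` differs from compound 3 by isoquinolin-4-yl in place of 2,6-dimethylpyrimidin-4-yl on an oxygen on a saturated carbon. Going by the values given here, no measured step bears on this change; the three unreadable steps give no direction and no size. The expected step of a number no higher from compound 3 to compound 4 (the limit leaves the size open) is accordingly set at none beyond the scatter, with the estimate for compound 4 in this assay put at 200000 nM, in the range 40000 nM to 1000000 nM, and most likely again only a limit.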

Compound 4, half-maximal inhibitory concentration: 166000 nM
Compound 4: the middle estimate sits 1.2-fold (0.08 log units) above what was measured; measured number inside the range.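

In this assay compound 4 gives 166000 nM, which makes (isoquinolin-4-yl)oxy the only group shown at this position to return a number rather than a limit. Going by these compounds, the steps read an at least 1.2-fold lower number from compound 3 to compound 4 (0.08 log units; that floor lies within the scatter), an at least 1.2-fold lower number from compound 2 to compound 4 (0.08 log units; that floor lies within the scatter) and an at least 1.2-fold lower number from compound 1 to compound 4 (0.08 log units; that floor lies within the scatter); each is only a floor, so the true size of each change stays open. The steps among the other three compounds cannot be read, and the series therefore still offers no ranking of those groups: the limit of > 200000 nM in this assay, at which 3 of the 4 values shown sit.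

The compounds shown leave open whether the carbon-only aromatic ring of isoquinolin-4-yl matters here, or the position of its ring nitrogen. On these data alone, how a quinolin-4-yl or a plain phenyl group on the same oxygen would read also remains open.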